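A few compounds are considered here, and "the series" means these few. Any claim that something is new, unique, unknown or untested is made for them only; others in the source may bear on it.

Measured so far in an ADME assay on HEK293 cells (Homo sapiens) for cytotoxicity, read by MTT assay, with a stated time of 48 h; on this read-out higher numbers stand for weaker inhibition and lower numbers for stronger inhibition:

compound 1 `Cc1nc(-c2ccc(Cl)cc2)sc1C(=O)CSc1nc(-c2ccc(Cl)c(Cl)c2)c(C#N)c(=O)[nH]1` - 46900 nM
compound 2 `Cc1nc(-c2ccc(Cl)cc2)sc1C(=O)CSc1nc(-c2cccc(Cl)c2)c(C#N)c(=O)[nH]1` - 30100 nM
compound 3 `COc1ccc(-c2nc(SCC(=O)c3sc(-c4ccc(Cl)cc4)nc3C)[nH]c(=O)c2C#N)cc1OC` - "not determined" (no result reported)

Compound 3 has no single number in this assay and so gives no starting value. Compound 4 `Cc1nc(-c2ccc(Cl)cc2)sc1C(=O)CSc1nc(-c2ccc(Cl)cc2)c(C#N)c(=O)[nH]1` differs from compound 3 by this change 4-chlorophenyl in place of 3,4-dimethoxyphenyl on an aromatic carbon and in words it carries 4-chlorophenyl in place of 3,4-dimethoxyphenyl on an aromatic carbon. Among the compounds with values here, the one measured step that bears on this aryl group is a 1.6-fold lower number from compound 1 to compound 2 (0.19 log units; within the scatter) and it stays within the scatter. Within the data shown here, no step from compound 3 can be sized, and no direction can be given. Compound 4 is instead expected to fall close to compound 1 at 46900 nM and compound 2 at 30100 nM with no gap beyond the scatter. Compound 4 is estimated at 36000 nM with an expected range from 18000 nM to 72000 nM around it.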

Compound 4, half-maximal inhibitory concentration: 75100 nM
Compound 4: the middle estimate sits 2.1-fold (0.32 log units) below what was measured; the whole stated range lies below it.
By their numbers in this assay, from the lowest: compounds 2, 1 and 4 (each within the scatter of the next, the first and the last beyond it).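

In this assay, within the data shown here, the change to 4-chlorophenyl from 3-chlorophenyl gives a 2.5-fold higher number from compound 2 to compound 4 (0.40 log units; beyond the scatter) as the first step in this set beyond the scatter, though only a modest one. Hydrogen in place of chloro gives a 1.6-fold higher number from compound 1 to compound 4 (0.20 log units; within the scatter) and stays within the scatter, so here the place of the chlorine shows more than a second chlorine does. Nothing available explains this difference. Compound 3 has no number, so 3,4-dimethoxyphenyl cannot be compared with 4-chlorophenyl at this position. On these data alone, how an amine or a carboxylic acid on this aryl ring would read remains open.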